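The compounds below may be only part of what the source reports. "The series", "measured", "known", "first", "only" and "open" are said of these compounds alone.

Three compounds of the shared core have numbers in an assay on HEK293 cells for inhibition of sodium-dependent dopamine transporter (Homo sapiens), read by scintillation counting, with stated times of 5 min and 1 min; on this read-out higher numbers stand for weaker inhibition and lower numbers for stronger inhibition. Compound 1 `[O-][S+](Cc1cc(C2CC2)on1)C(c1ccccc1)c1ccccc1` gives 38600 nM, compound 2 `[O-][S+](Cc1csc(Br)c1)C(c1ccccc1)c1ccccc1` gives 16600 nM, and compound 3 `[O-][S+](Cc1ccncc1)C(c1ccccc1)c1ccccc1` gives 63500 nM, the highest of the three numbers shown, with the nearest number at compound 1 and the furthest at compound 2. The change to compound 4 `[O-][S+](Cc1ccsc1)C(c1ccccc1)c1ccccc1` is thiophen-3-yl in place of pyridin-4-yl on a saturated chain carbon bound to a sulfur. Within the data shown here, the closest precedent is the opposite move with a bromine present, which gave a 3.8-fold higher number from compound 2 to compound 3 (0.58 log units; beyond the scatter), whereas a 1.6-fold higher number from compound 1 to compound 3 (0.22 log units; within the scatter) stays within the scatter. Reversing that move without the bromine, a modest fall in the number is expected in this assay. Compound 4 is therefore estimated at 30000 nM, with a range from 12000 nM to 75000 nM. The expected step is a 2.1-fold lower number from compound 3 to compound 4 (0.33 log units; beyond the scatter).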

Compound 4, half-maximal inhibitory concentration: 3000 nM
Beside the measured number, compound 4's estimate is 10-fold (1.00 log units) above it, and the stated range ends above it.
By their numbers in this assay, from the lowest: compound 4; then compound 2; then compounds 1 and 3 (each within the scatter of the next).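

In this assay thiophen-3-yl on a saturated chain carbon bound to a sulfur stands clearly apart from the other groups, with a 21-fold lower number from compound 3 to compound 4 (1.33 log units; beyond the scatter) and a 13-fold lower number from compound 1 to compound 4 (1.11 log units; beyond the scatter) both large. Bromo is no help here: hydrogen in its place gives a 5.5-fold lower number from compound 2 to compound 4 (0.74 log units; beyond the scatter) and so the thiophen-3-yl group does best with nothing on it among these compounds. Nothing shown accounts for the size of these steps. From the compounds shown here alone, whether a methyl or chloro group elsewhere on the thiophen-3-yl ring keeps this gain stays open, as does the effect of an amine or a carboxylic acid on that ring.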